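The source may report more compounds than this note shows. Statements on the series, on what has been measured and on what is new or still open speak of the compounds shown alone.

Compound 3 `CN(C)C(=O)c1cccc(Oc2cc(C(=O)O)cc(Oc3cc(C(=N)N)ccc3O)n2)c1` gives 300 nM in an assay on isolated protein for inhibition of serine protease 1 (Bos taurus); on this read-out higher numbers stand for weaker inhibition and lower numbers for stronger inhibition. Among the three compounds measured so far it holds the lowest number: compound 1 `N=C(N)c1cccc(Oc2cccc(Oc3cccc(C(=N)N)c3)n2)c1` gives 1100 nM in this assay, and compound 2 `N=C(N)c1ccc(Oc2nc(Oc3ccc(C(=N)N)cc3)c(Cl)cc2Cl)cc1` gives 2700 nM in this assay, and both gaps from compound 3 lie beyond the usual scatter of repeated measurements. Compound 4 `Cn1ccnc1-c1cccc(Oc2cc(C(=O)O)cc(Oc3cc(C(=N)N)ccc3O)n2)c1` has not yet been measured. It differs from compound 3 in one place: 1-methyl-1H-imidazol-2-yl in place of dimethylcarbamoyl on an aromatic carbon, meta to a large group. Among the compounds with values here, no measured pair shows this exchange, and nothing in the data sets its size or direction. With the rest of the structure kept, the step from compound 3 to compound 4 is expected to be small, staying within the scatter and favouring neither direction, as no change at the digits printed from compound 3 to compound 4 (within the scatter) expresses. Compound 4 is estimated at 300 nM in this assay, with a range from 100 nM to 900 nM, and the measurement will show where it actually falls.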

Compound 4, inhibition constant: 660 nM
The estimate for compound 4 lay 2.2-fold (0.34 log units) below the measured number; measured number inside the range.
By their numbers in this assay, from the lowest: compound 3; then compounds 4 and 1 (each within the scatter of the next); then compound 2.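

In this assay, within the data shown here, putting 1-methyl-1H-imidazol-2-yl in place of dimethylcarbamoyl on this aromatic carbon, meta to a large group, gives a 2.2-fold higher number from compound 3 to compound 4 (0.34 log units; beyond the scatter), the first step that can be read at any single position, as the earlier compounds offered no pair differing in one place. The step is modest but beyond the scatter, so this position is not indifferent to the exchange, and the direction favours dimethylcarbamoyl, although the five-membered aromatic ring still leaves weaker inhibition of only limited extent. No measurement at hand bears on why the number rises. The compounds shown leave open how a primary carboxamide, an imidazol-2-yl without the methyl, or a plain hydrogen on this carbon would compare with dimethylcarbamoyl. They also leave open whether the step would hold on a core lacking the carboxylic acid.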